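Swapping a Cyclopropyl for an Isopropyl on an Oxazole

A few compounds are considered here, and "the series" means these few. Any claim that something is new, unique, unknown or untested is made for them only; others in the source may bear on it.

Compound 2 `O=C(Nc1cc(C2CC2)on1)n1ccc2cc(Oc3ncnc4c3CNC4)ccc21` gives 98% in a functional assay on the whole organism (strain C57BL/6) for inhibition, with Mus musculus as the target, read by microscopy, with a stated time of 6 days, at a dose of 10 mg/kg by the oral route (a lower number here means less inhibition, a higher number more inhibition at the dose given (going by the name of the read-out)), the higher of the two numbers seen so far. Compound 1 `CC(C)(C)c1cc(NC(=O)n2ccc3cc(Oc4ncnc5c4CNC5)ccc32)on1` gives 58% in this assay, and the step of a number 40 percentage points higher from compound 1 to compound 2 (beyond the scatter) shows how strongly a change on the oxazole ring can move this read-out. Compound 3 `CC(C)c1cc(NC(=O)n2ccc3cc(Oc4ncnc5c4CNC5)ccc32)no1` differs from compound 2 by isopropyl in place of cyclopropyl on an aromatic carbon. Going by the values given here, only the step from compound 1 to compound 2 bears on this, and only loosely, since it alters both the attachment point of the oxazole and the group on it, whereas here only the small carbon group changes. With compound 2 already near the top of the percentage scale, a small decrease is expected for compound 3, a number 10 percentage points lower from compound 2 to compound 3 (within the scatter), likely within the scatter. Compound 3 is therefore estimated at 88% in this assay, with a range from 65% to 100%.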

Compound 3, a percentage reported as inhibition, in the whole organism at one dose (the size of the read-out at that dose, not a potency) in the Mus musculus assay: 96%
Estimate against measurement, compound 3: 8 percentage points below, and the stated range covers the measured number.
By their numbers in the Mus musculus assay, from the lowest: compound 1; then compounds 3 and 2 (each within the scatter of the next).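

In the Mus musculus assay the ring of cyclopropyl proves unnecessary at this position, since the group without a ring gives a number 2 percentage points lower from compound 2 to compound 3 (within the scatter), and the change of oxazole attachment and group together still gives a number 38 percentage points higher from compound 1 to compound 3 (beyond the scatter). In a physicochemical assay for solubility, at pH 6.8 (a higher number here means a more soluble compound, a lower number a less soluble compound), compound 2 gives 110000 nM and compound 3 gives 37000 nM. The two groups, alike in heavy atom count, are therefore told apart by solubility, although not by the Mus musculus assay: the measured solubility of compound 2, 110000 nM, and of compound 3, 37000 nM, a 3.0-fold lower number (0.47 log units; beyond the scatter)

Still open, as far as these compounds go, is whether a group of another kind on this aromatic carbon, such as an amine or a longer chain, would keep the inhibition and how solubility would follow. With compound 2 and compound 3 both near the top of the percentage scale, this single dose also cannot show whether they would separate at a lower one.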